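Fluorine removal on the compound 2 core

The source may hold more compounds than are shown below. What is called first, only, known or untested is meant among the compounds shown, and "the series" means these compounds.

Measured in a functional assay on CHO-K1 cells for agonist activity at Glucose-dependent insulinotropic receptor (Homo sapiens), read by a luciferase reporter, with a stated time of 5 h; a lower number here means that less compound is needed, a higher number that more compound is needed for the effect:
compound 1 `CC(C)OC(=O)N1CCC(Oc2cccc3c2CCN3c2ccc(S(C)(=O)=O)cc2)CC1`: 501 nM
compound 2 `CC(C)OC(=O)N1CCC(Oc2ncnc3c2CCN3c2ccc(S(C)(=O)=O)cc2F)CC1`: 50.1 nM
compound 3 `CC(C)OC(=O)N1CCC(Oc2cccc3c2CCN3c2ccc(S(C)(=O)=O)cc2F)CC1`: 1000 nM

Compound 2 gives the lowest number of the three; compound 1 and compound 3 both lie beyond the scatter above it. Going by the values given here, the only single-point step among the measured compounds is a 2.0-fold higher number from compound 1 to compound 3 (0.30 log units; within the scatter), fluoro entering on the core of compound 1, and that step lies within the scatter.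

Compound 4 `CC(C)OC(=O)N1CCC(Oc2ncnc3c2CCN3c2ccc(S(C)(=O)=O)cc2)CC1` is not yet measured. Relative to compound 2 it has hydrogen in place of fluoro on an aromatic carbon. Among the compounds with values here, this is the reverse of the change seen in a 2.0-fold higher number from compound 1 to compound 3 (0.30 log units; within the scatter), there on a different core; the pair of compound 2 and compound 4 is the only one carrying the change on the compound 2 core, so whether both cores respond alike is not known. On the measured step the expectation for this assay is a change of no more than the scatter, if anything toward a lower number. Compound 4 is therefore estimated at 35 nM, with a range of 15 nM to 110 nM. The step this estimate means is a 1.4-fold lower number from compound 2 to compound 4 (0.16 log units; within the scatter).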

Compound 4, half-maximal effective concentration: 126 nM
The estimate for compound 4 lay 3.6-fold (0.56 log units) below the measured number; measured number outside the range, above it.
By their numbers in this assay, from the lowest: compound 2; then compound 4; then compounds 1 and 3 (each within the scatter of the next).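

In this assay, going from 2-fluoro-4-(methylsulfonyl)phenyl to 4-(methylsulfonyl)phenyl on the core of compound 2 gives a 2.5-fold higher number from compound 2 to compound 4 (0.40 log units; beyond the scatter). The step is modest, but it shows that fluoro at this position, on an aromatic carbon ortho to a large group and meta to the methylsulfonyl group, can register beyond the scatter, which the step on the core of compound 1 did not show. The response to this change therefore differs between the two cores: the same change on two cores in this assay, a 2.0-fold higher number (0.30 log units; within the scatter) from compound 1 to compound 3 and a 2.5-fold lower number (0.40 log units; beyond the scatter) from compound 4 to compound 2, 5.0-fold (0.70 log units) apart, beyond the scatter of two such steps.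

Only hydrogen and fluoro are shown at this position, so how chloro, methoxy or a nitrile would read on the core of compound 2 stays open. Going by these compounds, the difference between cores rests on two pairs, and how the change would read on any third core is also open.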